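This account rests on a few compounds, and the source may have more. Where it says the series, first, only, none or still open, it means among the compounds named here.

The series shares one core, a hydroxy-substituted naphthoquinone linked through an ester and a short chain to a sulfonyl-bearing furoxan. Compound 1 `CC1=C(C(C)CC(=O)OCC(C)COc2no[n+]([O-])c2S(=O)(=O)c2ccccc2)C(=O)c2c(O)cccc2C1=O` gives 91.5% in a functional assay on HepG2 cells (Homo sapiens) for inhibition, read by MTT assay, with a stated time of 72 h, tested at 10 uM; on this read-out lower numbers stand for less inhibition of growth and higher numbers for more inhibition of growth at the one concentration tested. Compound 2 `CC1=C(CCC(=O)OCCOc2no[n+]([O-])c2S(=O)(=O)c2ccccc2)C(=O)c2c(O)cccc2C1=O` gives 95.7% in this assay, and compound 3 `CC1=C(CCC(=O)OCCCOc2no[n+]([O-])c2S(=O)(=O)c2ccccc2)C(=O)c2c(O)cccc2C1=O` gives 95.1% in this assay. All three numbers fall within the usual scatter of one another, so compound 3 stands in a tight cluster with compound 1 and compound 2, with no ordering among them that the measurements can support.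

Compound 4 `CC1=C(CCC(=O)OCC(C)COc2no[n+]([O-])c2S(=O)(=O)c2ccccc2)C(=O)c2c(O)cccc2C1=O` has not yet been measured in this assay. It differs from compound 3 by methyl in place of hydrogen on a saturated chain carbon bound to two saturated chain carbons. Going by the values given here, no step between two measured compounds isolates this change, so there is nothing in the data to point to a direction. Given that compound 1, which carries the same branched chain together with a further methyl on the core, gives 91.5%, the step is expected to be a number 2.1 percentage points lower from compound 3 to compound 4 (within the scatter), none beyond the scatter. Compound 4 is therefore estimated to give 93% in this assay, with a likely range from 84% to 99%.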

Compound 4, percent growth inhibition at one concentration: 73.4%
Beside the measured number, compound 4's estimate is 19.6 percentage points above it; measured number outside the range, below it.
By their numbers in this assay, from the lowest: compound 4; then compounds 1, 3 and 2 (each within the scatter of the next).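

In this assay, methyl in place of hydrogen on a saturated chain carbon bound to two saturated chain carbons brings a number 21.7 percentage points lower from compound 3 to compound 4 (beyond the scatter) and shows that the chain does not tolerate every small change, something the tight cluster of earlier compounds could not reveal. The second step qualifies this, since hydrogen in place of methyl on a saturated chain carbon bound to a double-bonded ring carbon and a saturated chain carbon brings a number 18.1 percentage points lower from compound 1 to compound 4 (beyond the scatter) and so the branched chain gives a high number in compound 1 and a clearly lower one in compound 4, which means the effect of the chain methyl depends on what else the molecule carries. Nothing available here accounts for either step.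

What the compounds shown leave open is whether the fall belongs to methyl specifically or would also follow from an ethyl group or a hydroxyl group on the same chain carbon. They also leave open whether a longer chain carrying the same methyl would behave like compound 4 or like compound 1 in this assay at this one concentration.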